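This account rests on a few compounds, and the source may have more. Where it says the series, first, only, none or still open, it means among the compounds named here.

Three compounds share one core and differ only in the group attached through the ether oxygen. Compound 1 `O=c1ccoc2ccc(OCCc3ccccc3)cc12` carries a phenethyl chain and in an assay on microsomes for inhibition of Amine oxidase [flavin-containing] B (Homo sapiens), read by fluorescence and spectrophotometry, with a stated time of 20 min (a lower number here means a stronger inhibitor, a higher number a weaker inhibitor), compound 1 gives 21 nM. Compound 2 `O=c1ccoc2ccc(OCc3cccc(Cl)c3)cc12` gives 3.6 nM, the second highest of the three numbers, within the scatter of compound 3 `O=c1ccoc2ccc(OCc3ccc(Br)cc3)cc12`, which gives 3.3 nM, and well apart from compound 1. Compound 4 `Cc1cccc(COc2ccc3occc(=O)c3c2)c1` is not yet measured; it differs from compound 2 by methyl in place of chloro on an aromatic carbon. Going by the values given here, no measured pair here differs in one place only, so the step from compound 2 to compound 4 has no direct precedent; a change of this kind is expected to stay close to the scatter, as a 1.4-fold higher number from compound 2 to compound 4 (0.14 log units; within the scatter). For compound 4 the estimate is 5 nM, between 2 nM and 15 nM.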

Compound 4, half-maximal inhibitory concentration: 19 nM
Estimate against measurement, compound 4: 3.8-fold (0.58 log units) below; measured number above the stated range.
By their numbers in this assay, from the lowest: compounds 3 and 2 (each within the scatter of the next); then compounds 4 and 1 (each within the scatter of the next).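

Going by these compounds alone, this is the first pair here that differs in one place only, and it shows that this spot on the aromatic ring is sensitive to what sits on it: methyl in place of chloro gives a 5.3-fold higher number from compound 2 to compound 4 (0.72 log units; beyond the scatter) and this step lies beyond the scatter. Yet the two groups count the same number of heavy atoms, and neither brings a hydrogen-bond donor or acceptor. Nothing available gives a reason for the step. Still open, on these data alone, is how fluoro, methoxy or an amine would fare at this spot, and whether methyl in place of bromo on compound 3 would give a similar step.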